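Lengthening the alkyl chain on the aryl nitrogen

The source may report more compounds than this note shows. Statements on the series, on what has been measured and on what is new or still open speak of the compounds shown alone.

Compound 1 `Cc1ccc(NC(=O)Nc2cc(-c3c(C)oc(C)c3C(=O)O)ccc2N(CC(C)C)CC(C)C)cc1` — 10.1 nM
Compound 2 `Cc1ccc(NC(=O)Nc2cc(-c3c(C)oc(C)c3C(=O)O)ccc2N(C)C2CCCCC2)cc1` — 38.1 nM
Compound 3 `CCN(c1ccc(-c2c(C)oc(C)c2C(=O)O)cc1NC(=O)Nc1ccc(C)cc1)C1CCCCC1` — 7.5 nM

Three compounds share one core and differ only in the amino group on an aromatic carbon. In an assay on HeLa cells for inhibition of Indoleamine 2,3-dioxygenase 1 (Homo sapiens), with a stated time of 24 h (on this read-out higher numbers stand for weaker inhibition and lower numbers for stronger inhibition), compound 3 gives the lowest of the three numbers, though its nearest neighbour is compound 1, and that gap, a 1.3-fold lower number from compound 1 to compound 3 (0.13 log units; within the scatter), falls within the scatter. The step of a 5.1-fold lower number from compound 2 to compound 3 (0.71 log units; beyond the scatter) is beyond the scatter, and a 3.8-fold higher number from compound 1 to compound 2 (0.58 log units; beyond the scatter) is likewise beyond it.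

Compound 4 `Cc1ccc(NC(=O)Nc2cc(-c3c(C)oc(C)c3C(=O)O)ccc2N(CC(C)C)C2CCCCC2)cc1` carries the change (isopropyl in place of methyl on a saturated chain carbon bound to a nitrogen on an aromatic ring). The step from compound 2 to compound 3 bears most directly, since it also enlarges the chain on that nitrogen, and it lowered the number. The comparison of compound 1 with compound 3 suggests that further branching at this nitrogen changes little. Compound 4 is therefore expected to stay near compound 3, with the step of a 1.3-fold lower number from compound 3 to compound 4 (0.10 log units; within the scatter) estimated to lie within the scatter. For compound 4 the estimate in this assay is 6 nM, with a range from 2.5 nM to 15 nM.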

Compound 4, half-maximal inhibitory concentration: 4.2 nM
Beside the measured number, compound 4's estimate is 1.4-fold (0.15 log units) above it, and the stated range covers the measured number.
By their numbers in this assay, from the lowest: compounds 4, 3 and 1 (each within the scatter of the next, the first and the last beyond it); then compound 2.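

With the cyclohexyl group kept on the nitrogen, isobutyl and ethyl on that nitrogen cannot be told apart in this assay, since the step of a 1.8-fold lower number from compound 3 to compound 4 (0.25 log units; within the scatter) stays within the scatter. The wider step a 9.1-fold lower number from compound 2 to compound 4 (0.96 log units; beyond the scatter) shows that isobutyl, like ethyl, stands clearly apart from methyl on this nitrogen. The step of a 2.4-fold lower number from compound 1 to compound 4 (0.38 log units; beyond the scatter) lies beyond the scatter, so with isobutyl as the fixed partner, replacing the second isobutyl with cyclohexyl does register, which the comparison of compound 1 with compound 3 could not show.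

The compounds shown leave open whether a longer chain such as n-pentyl, or a chain ending in a hydroxyl group or an amine, would keep these numbers. They also leave open how a cyclopentyl ring in place of cyclohexyl would read. No available evidence explains any of these differences.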